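Adding a methyl on the side chain: tolerability in cells

A few compounds are considered here, and "the series" means these few. Any claim that something is new, unique, unknown or untested is made for them only; others in the source may bear on it.

Measured compounds:
- compound 1, `CC(c1ccccc1)c1cc(O)nc(SC2CCCC2)n1`, a functional assay on MT4 cells (Homo sapiens) for cytotoxicity; a lower number here means that less compound is tolerated, a higher number that more compound is tolerated: 159000 nM
- compound 2, `CCC(c1ccccc1)c1cc(O)nc(SC2CCCC2)n1`, this assay: 50000 nM
- compound 3, `CC(c1cc(O)nc(SC2CCCC2)n1)c1c(Cl)cccc1Cl`, this assay: 78300 nM

Compounds 1 and 2 share one core, and the only difference between them is methyl in place of hydrogen on a saturated chain carbon, two bonds along the chain from two aromatic carbons. This change brought a 3.2-fold lower number from compound 1 to compound 2 (0.50 log units; beyond the scatter), so compound 2 is tolerated at a lower concentration than compound 1.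

Compound 3 carries a different core; the difference between the two cores is not broken down here. In this assay compound 3 gives 78300 nM, which lies within the usual scatter of the number for compound 2 and is somewhat lower than that of compound 1.

Compound 4, `CCC(c1cc(O)nc(SC2CCCC2)n1)c1c(Cl)cccc1Cl`, is not yet measured. It relates to compound 3 exactly as compound 2 relates to compound 1: the difference is methyl in place of hydrogen on a saturated chain carbon, two bonds along the chain from two aromatic carbons, and the place of the change is the same in both pairs. Because a 3.2-fold lower number from compound 1 to compound 2 (0.50 log units; beyond the scatter) lowered the number on the first core, a step of similar size is expected on the second core, namely a 3.0-fold lower number from compound 3 to compound 4 (0.48 log units; beyond the scatter). This rests on a single earlier pair, so the expectation carries real uncertainty. Compound 4 is therefore estimated at 26000 nM, with a likely range from 10000 nM to 65000 nM.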

Compound 4, half-maximal cytotoxic concentration: 70000 nM
Beside the measured number, compound 4's estimate is 2.7-fold (0.43 log units) below it; the measured number lies above the stated range.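

In this assay, adding the methyl did not do the same thing on the two cores: the same change on two cores in this assay, a 3.2-fold lower number (0.50 log units; beyond the scatter) from compound 1 to compound 2 and a 1.1-fold lower number (0.05 log units; within the scatter) from compound 3 to compound 4, 2.8-fold (0.45 log units) apart, beyond the scatter of two such steps. On the core that carries 2,6-dichlorophenyl, the methyl gives a 1.1-fold lower number from compound 3 to compound 4 (0.05 log units; within the scatter), so the clear drop seen on the core of compound 1 did not carry over, and a step measured on one core proved a poor guide to the other in this pair of cores. With the methyl in place, 2,6-dichlorophenyl in place of phenyl gives a 1.4-fold higher number from compound 2 to compound 4 (0.15 log units; within the scatter), which is also within the usual scatter, but two pairs of compounds cannot show why the cores differ, nor which of the two results a further core would follow.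

On these data alone, it remains open whether a longer chain such as propyl, put in the same place as the methyl, would lower the number on either core or leave it where it is. Also open, as far as these compounds go, is how the methyl would behave on a phenyl carrying a single chlorine, which would help show whether one chlorine is enough for the step to stay within the scatter.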